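Swapping a Thiazolyl Amide for a Quinolinyl Amide

A few compounds are considered here, and "the series" means these few. Any claim that something is new, unique, unknown or untested is made for them only; others in the source may bear on it.

Measured compounds:
Compound 1, `CCCCCCNC(=O)NS(=O)(=O)N1CCC(CNC(=O)c2cc(Cl)ccc2OC)CC1`: 17%
Compound 2, `Cc1ncsc1C(=O)NCCC1CCN(S(=O)(=O)NC(=O)NC[C@@H]2C[C@@H]3C=C[C@@H]2C3)CC1`: 11%
Compound 3, `CCCNC(=O)NS(=O)(=O)N1CCC(CCNC(=O)c2cscn2)CC1`: 10%

All three compounds were tested in a functional assay on the whole organism (blood) with Rattus norvegicus as the target, with stated times of 24 h and 1 h, at a dose of 5 mg/kg by the intraperitoneal route; on this read-out higher numbers stand for a stronger effect at the one dose given and lower numbers for a weaker effect. Compound 1 gives 17%, compound 2 gives 11% and compound 3 gives 10%. Compound 2 lies within the scatter of both others: compound 3 is nearest and compound 1 furthest, yet neither gap is larger than the scatter, so the three numbers cannot be told apart with confidence. Among the measured compounds shown here, none of the three compounds differs from another in one place only, so no single structural step has been measured.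

The untested compound 4, `O=C(NC[C@@H]1C[C@@H]2C=C[C@@H]1C2)NS(=O)(=O)N1CCC(CCNC(=O)c2ccc3ccccc3n2)CC1`, differs from compound 2 in one place: quinolin-2-yl in place of 4-methyl-1,3-thiazol-5-yl on a carbonyl carbon. The change sits on a carbonyl carbon whose other neighbour is an amide-type nitrogen. For the measured compounds named here, with no measured step to lean on, and with all three known numbers clustered within the scatter, the change is expected to produce a step of a number 2 percentage points higher from compound 2 to compound 4 (within the scatter) in this assay, that is, nothing beyond the scatter. Compound 4 is therefore estimated at 13%, with a range from 4% to 24%.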

Compound 4, a percentage reported as activity, at one dose (the size of the read-out at that dose, not a potency): 21%
Beside the measured number, compound 4's estimate is 8 percentage points below it; the range from low to high includes it.
By their numbers in this assay, from the lowest: compounds 3, 2, 1 and 4 (each within the scatter of the next, the first and the last beyond it).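

Among these compounds, only one pair differs in a single place, so this is the only direct reading of a change at this position in this assay. Replacing 4-methyl-1,3-thiazol-5-yl with quinolin-2-yl on a carbonyl carbon whose other neighbour is an amide-type nitrogen gives a step (a number 10 percentage points higher from compound 2 to compound 4 (within the scatter)), so a two-ring group of 10 heavy atoms can stand where a one-ring group of 6 stood without the two numbers being told apart. No measurement available here explains this reading.

On these data alone, whether a single six-membered ring such as pyridin-2-yl, or a group without a ring such as a longer chain, would read the same on this carbonyl carbon remains open. Also open, as far as these compounds go, is whether quinolin-2-yl would behave alike on the cores of compound 1 and compound 3.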